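Dienone–coumarin triazole conjugates: removing an aryl methoxy group

This account rests on a few compounds, and the source may have more. Where it says the series, first, only, none or still open, it means among the compounds named here.

Compound 2 `COc1ccc(/C=C/C(=O)/C=C/c2ccc(OCc3cn(CCOc4cc(=O)oc5ccccc45)nn3)c(OC)c2)cc1OC`, compound 1 `COc1cccc(/C=C/C(=O)/C=C/c2ccc(OCc3cn(CCOc4cc(=O)oc5ccccc45)nn3)c(OC)c2)c1` and compound 3 `COc1ccccc1/C=C/C(=O)/C=C/c1ccc(OCc2cn(CCCCCOc3cc(=O)oc4ccccc34)nn2)c(OC)c1` have been measured in a functional assay on COLO 205 cells (Homo sapiens) for inhibition, read by sulforhodamine B assay, with a stated time of 48 h, tested at 50 uM; on this read-out higher numbers stand for more inhibition of growth at the one concentration tested and lower numbers for less inhibition of growth. Compound 2 gives 80%, compound 1 gives 69% and compound 3 gives 30%. Compound 1 differs from compound 2 by hydrogen in place of methoxy on an aromatic carbon, and this step reads a number 11 percentage points lower from compound 2 to compound 1 (beyond the scatter). Compound 3 carries a different core; how that core differs from the core of compound 2 is not broken down here, and its value is the lowest of the three.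

Compound 4 `COc1cc(/C=C/C(=O)/C=C/c2ccccc2)ccc1OCc1cn(CCCCCOc2cc(=O)oc3ccccc23)nn1` is not yet measured and differs from compound 3 by hydrogen in place of methoxy on an aromatic carbon. The place differs from that in compound 1: there the carbon was ortho to a methoxy group and para to a large group, here it is ortho to a large group, so this is the same kind of change, not the same.

For compound 4 the expected step in this assay is a number 8 percentage points lower from compound 3 to compound 4 (within the scatter). This rests on the earlier removal of a methoxy, which made a step of a number 11 percentage points lower from compound 2 to compound 1 (beyond the scatter), while compound 3 starts from a low level and the surroundings of the place differ. Compound 4 is therefore expected to give about 22%, between 5% and 45%.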

Compound 4, percent growth inhibition at one concentration: 22%
Compound 4: middle estimate and measured number agree at the digits printed, and the stated range covers the measured number.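

In this assay hydrogen in place of methoxy on an aromatic carbon gives a number 8 percentage points lower from compound 3 to compound 4 (within the scatter) and so, on this core, the step cannot be told apart from repeat scatter. Set beside the earlier step, the change carries from one core to the other without a size difference that can be resolved: the same change on two cores in this assay, a number 11 percentage points lower (beyond the scatter) from compound 2 to compound 1 and a number 8 percentage points lower (within the scatter) from compound 3 to compound 4, 3 percentage points apart, within the scatter of two such steps. This rests on two pairs only, with the methoxy leaving a different place in each and the two pairs starting from different levels, so it does not show that the step is constant across the series or that it is independent of place.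

Open, on these data alone, is how other groups at the place ortho to a large group would read, for example a hydroxy group, a fluorine or a dimethylamino group. Also open, as far as these compounds go, is whether the step holds with a longer chain, and whether it holds at other concentrations, since a single concentration gives no full dose-response curve.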